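This account rests on a few compounds, and the source may have more. Where it says the series, first, only, none or still open, it means among the compounds named here.

Series notes. Compound 1 `Cn1ccc2ccc(-c3cc(Nc4ccccc4S(N)(=O)=O)cc4nccnc34)cc21` gives 265 nM in an assay for inhibition of 6-phosphofructo-2-kinase/fructose-2,6-bisphosphatase 3 (Homo sapiens), read by ADP-Glo, with a stated time of 2 h; a lower number here means a stronger inhibitor, a higher number a weaker inhibitor. Within the data shown here, compound 2 `CNC(=O)c1ccncc1Nc1cc(-c2ccc3ccn(C)c3c2)c2nccnc2c1` gives 83 nM in this assay; this is the lowest of the two numbers so far, the only measured step being a 3.2-fold lower number from compound 1 to compound 2 (0.50 log units; beyond the scatter). Compound 3 `Cn1ccc2ccc(-c3cc(Nc4cnccc4C(=O)NC4CCNC(=O)C4)cc4nccnc34)cc21` has not yet been measured. It differs from compound 2 by 2-oxopiperidin-4-yl in place of methyl on an amide-type nitrogen. Among the measured compounds shown here, the single measured step, a 3.2-fold lower number from compound 1 to compound 2 (0.50 log units; beyond the scatter), exchanges the whole group on a nitrogen on an aromatic ring, not the substituent on the amide-type nitrogen, so it bears only loosely on the present change: it shows that this region of the molecule accepts alteration without loss, but says nothing about the amide substituent itself. For the measured compounds named here, with no closer precedent, a step of a 1.1-fold lower number from compound 2 to compound 3 (0.04 log units; within the scatter) is expected, within the scatter. For compound 3 the estimate in this assay is 75 nM, with a range of 25 nM to 220 nM.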

Compound 3, half-maximal inhibitory concentration: 69 nM
For compound 3 the middle estimate is 1.1-fold (0.04 log units) above the measured one; the range from low to high includes it.
By their numbers in this assay, from the lowest: compounds 3 and 2 (each within the scatter of the next); then compound 1.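

On the amide-type nitrogen, 2-oxopiperidin-4-yl in place of methyl gives a 1.2-fold lower number from compound 2 to compound 3 (0.08 log units; within the scatter) in this assay, so compound 2 and compound 3 cannot be told apart here. Among these compounds, this is the only reading on the amide substituent itself: a group of 7 heavy atoms, with a six-membered non-aromatic ring, 1 hydrogen-bond donor and 1 hydrogen-bond acceptor, can replace a single methyl carbon with no measurable loss. No measurement shown accounts for this result.

From the compounds shown here alone, whether other groups on this nitrogen behave the same way remains open, for example an aminoethyl chain, a carboxylic acid on a longer chain or piperidin-4-yl without the ring carbonyl. Compound 3 brings in the ring, donor and acceptor together, and the compounds shown do not separate their contributions.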